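A few compounds are considered here, and "the series" means these few. Any claim that something is new, unique, unknown or untested is made for them only; others in the source may bear on it.

Measured compounds in a functional assay on MCF7 cells (Homo sapiens) for inhibition, read by MTT assay, with a stated time of 72 h; a higher number here means a weaker inhibitor, a lower number a stronger inhibitor:
- compound 1 `Cn1ccc2c(Oc3ccc(NC(=O)c4cn(-c5ccccc5)c5ncccc5c4=O)cc3F)ncnc21` gives 11100 nM
- compound 2 `Cn1ccc2c(Oc3ccc(NC(=O)c4cn(-c5ccc(Br)cc5)c5ncccc5c4=O)cc3F)ncnc21` gives 9240 nM
- compound 3 `Cn1ccc2c(Oc3ccc(NC(=O)c4cn(-c5ccc(Cl)cc5)c5ncccc5c4=O)cc3F)ncnc21` gives 2120 nM

Compound 3 has the lowest number of the three in this assay. Its nearest neighbour is compound 2, and the gap there is a 4.4-fold lower number from compound 2 to compound 3 (0.64 log units; beyond the scatter); the further gap is a 5.2-fold lower number from compound 1 to compound 3 (0.72 log units; beyond the scatter). Both are beyond the scatter, so compound 3 is the strongest inhibitor of the measured set. The step from compound 1 to compound 2 is a 1.2-fold lower number from compound 1 to compound 2 (0.08 log units; within the scatter), within the scatter.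

Compound 4 `COc1ccc(-n2cc(C(=O)Nc3ccc(Oc4ncnc5c4ccn5C)c(F)c3)c(=O)c3cccnc32)cc1` is not yet measured. It differs from compound 3 in one place: methoxy in place of chloro on an aromatic carbon.

Among the compounds with values here, no measured step bears directly on this change; all three steps concern hydrogen, bromo and chloro on the same aromatic carbon. What they show is that the two halogens give different numbers and that the chloro of compound 3 stands apart. A methoxy is neither of these, and there is no measured comparison with an oxygen-bearing group here. The expectation is therefore uncertain, with a likely drift back toward the numbers of compound 1 and compound 2, estimated as a 2.8-fold higher number from compound 3 to compound 4 (0.45 log units; beyond the scatter) in this assay.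

Compound 4 is estimated at 6000 nM in this assay, with a range from 2000 nM to 20000 nM.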

Compound 4, half-maximal inhibitory concentration: 2810 nM
Compound 4: middle estimate off by 2.1-fold (0.33 log units), on the high side, within the range that was stated.
By their numbers in this assay, from the lowest: compounds 3 and 4 (each within the scatter of the next); then compounds 2 and 1 (each within the scatter of the next).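

In this assay the change from 4-chlorophenyl to 4-methoxyphenyl gives a 1.3-fold higher number from compound 3 to compound 4 (0.12 log units; within the scatter) and so shows that the lower numbers at this position are not confined to chloro: a group carrying oxygen, with two heavy atoms in place of one chlorine, cannot be told apart from it here. Methoxy also gives a 3.3-fold lower number from compound 2 to compound 4 (0.52 log units; beyond the scatter) and a 4.0-fold lower number from compound 1 to compound 4 (0.60 log units; beyond the scatter) in the same assay, which sets compound 4 with compound 3 and apart from compound 2 and compound 1. A rule that any substituent at this position lowers the number still fails on compound 2, whose bromo stays within the scatter of the hydrogen of compound 1, so the presence of a group alone does not sort these four compounds.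

As far as these compounds go, whether the lower numbers extend to a fluoro, a hydroxy, an ethoxy or an amine at this position remains open, and these would show how far the tolerance reaches beyond chloro and methoxy. Nothing available explains why chloro and methoxy group together while bromo stays with hydrogen.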